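Replacing the Nitrophenyl Arm at the Sulfonyl Sulfur

The compounds below may be only part of what the source reports. "The series", "measured", "known", "first", "only" and "open" are said of these compounds alone.

In a functional assay (Cavia porcellus) with sulfonylurea receptors; K-ATP channels (Homo sapiens) as the target (on this read-out lower numbers stand for stronger inhibition and higher numbers for weaker inhibition), compound 1 `COc1ccc(S(=O)(=O)c2ccc(NC(=O)C(C)(O)C(F)(F)F)cc2)cc1` gives > 30000 nM, which is a limit of the assay and not a number. Compound 2 `CC(O)(C(=O)Nc1ccc(S(=O)(=O)c2ccc([N+](=O)[O-])cc2)cc1)C(F)(F)F` in this assay gives > 30000 nM, likewise only a limit. Among the measured compounds shown here, the single change between them, a step that the two limits leave unreadable from compound 1 to compound 2, therefore cannot be read; what is known is the limit of > 30000 nM in this assay, at which 2 of the 2 values shown sit. Compound 2 thus stands at the limit of this assay, alongside compound 1, without a measured number of its own.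

Compound 3 `CN(c1ccccc1)S(=O)(=O)c1ccc(NC(=O)C(C)(O)C(F)(F)F)cc1` differs from compound 2 in one place: methyl(phenyl)amino in place of 4-nitrophenyl on a sulfonyl sulfur. For the measured compounds named here, no measured step bears directly on this change, and the one step that exists, from methoxy to nitro, has no readable size. With compound 2 sitting at the limit, the step of a number no higher from compound 2 to compound 3 (the limit leaves the size open) in this assay is expected to be small, with no direction beyond the scatter that the data could support. Compound 3 is estimated at 30000 nM, within 5000 nM to 100000 nM, and the result is expected quite possibly to be only a limit again.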

Compound 3, half-maximal inhibitory concentration: 2000 nM
The estimate for compound 3 lay 15-fold (1.18 log units) above the measured number; the whole stated range lies above it.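

Among the compounds shown here, the sulfonyl sulfur is the first place where a change gives a readable result in this assay. Methyl(phenyl)amino in place of 4-nitrophenyl gives an at least 15-fold lower number from compound 2 to compound 3 (1.17 log units; beyond the scatter), and methyl(phenyl)amino in place of 4-methoxyphenyl gives an at least 15-fold lower number from compound 1 to compound 3 (1.17 log units; beyond the scatter), so the same entering group produces a large step against either arm, whereas the swap of methoxy for nitro on an aromatic carbon gave a step that cannot be read. Both new steps are minimum sizes only, and their true sizes stay unknown because compound 1 and compound 2 give no numbers of their own: the limit of > 30000 nM in this assay, at which 2 of the 3 values shown sit.

The compounds shown leave open which part of methyl(phenyl)amino goes with the step, the methyl on the nitrogen, the phenyl ring or the nitrogen itself, and whether an ethyl group in place of that methyl, or a benzyl group in place of that phenyl, would keep it. They also leave open whether the shared core carries the same step with other groups on its amide side, such as an amine.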